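This account rests on a few compounds, and the source may have more. Where it says the series, first, only, none or still open, it means among the compounds named here.

Measured compounds:
- compound 1, `COC(=O)C1=C(C)NC(=O)NC1c1ccccc1`, in an assay for inhibition of beta-glucuronidase (Bos taurus), read by spectrophotometry, with a stated time of 30 min; a lower number here means a stronger inhibitor, a higher number a weaker inhibitor: "not active" (no number reported)
- compound 2, `COC(=O)C1=C(C)NC(=O)NC1c1ccc(O)cc1`, in this assay: 17200 nM

Compound 1 stands without a number: in this assay compound 1 is reported as "not active" (no number reported), so no half-maximal inhibitory concentration can be placed beside it. Among the compounds with values here, compound 2 is the only member with a measured value, and in this assay compound 2 gives 17200 nM, a weak inhibition. No counted difference between compound 1 and compound 2 is given, so only their two readings can be set side by side.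

Compound 3, `CCC1NC(=O)NC(C)=C1C(=O)OC`, is not yet measured. It differs from compound 1 by ethyl in place of phenyl on a saturated ring carbon. With compound 1 inactive and compound 2 only weakly active, no change toward stronger inhibition is expected from this step, and a reading of no activity is the likelier outcome. Compound 3 is therefore estimated at 60000 nM in this assay, within a range of 15000 nM to 250000 nM.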

Compound 3, half-maximal inhibitory concentration: 52200 nM
Compound 3: the middle estimate sits 1.1-fold (0.06 log units) above what was measured, within the range that was stated.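

No step can be read between compound 1 and compound 3: compound 1 has no number, while compound 3 gives 52200 nM as its reading. On these data alone, how ethyl in place of phenyl alters inhibition stays open, and no evidence here bears on the result.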